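This account rests on a few compounds, and the source may have more. Where it says the series, first, only, none or still open, it means among the compounds named here.

Among the compounds with values here, in a functional assay on Caco-2 cells (Homo sapiens) for inhibition, read by MTT assay, with a stated time of 72 h (a higher number here means a weaker inhibitor, a lower number a stronger inhibitor), compound 1 `CC(C)CNC(=C\C(=O)/C=C/c1ccc(O)cc1)/C=C/c1ccc(O)cc1` gives 23000 nM, the only actual number so far. Compound 2 `COc1cc(/C=C/C(=O)/C=C(/C=C/c2ccc(O)c(OC)c2)NC2CCCCC2)ccc1O` is reported only as a limit, > 25000 nM. Compound 3 `CCC(C)NC(=C\C(=O)/C=C/c1ccc(OC(C)=O)c(OC)c1)/C=C/c1ccc(OC(C)=O)c(OC)c1` is also reported only as a limit, > 25000 nM. Compound 1 therefore has no exact comparison, as the other two sit at the limit of > 25000 nM in this assay, at which 2 of the 3 values shown sit. Compound 4 `O=C(/C=C(/C=C/c1ccc(O)cc1)NC1CCCCC1)/C=C/c1ccc(O)cc1` differs from compound 1 by one change, cyclohexyl in place of isobutyl on an amine nitrogen. Within the data shown here, no measured pair isolates this change, so no shift beyond the usual scatter is expected in this assay, and a result reported only as a limit remains quite possible. The estimated step is a 1.2-fold lower number from compound 1 to compound 4 (0.06 log units; within the scatter). For compound 4, the estimated value is 20000 nM, with an expected range of 10000 nM to 40000 nM.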

Compound 4, half-maximal inhibitory concentration: 7800 nM
Compound 4: middle estimate off by 2.6-fold (0.41 log units), on the high side, and the stated range ends above it.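

In this assay, within the data shown here, putting cyclohexyl in place of isobutyl on the amine nitrogen gives a 2.9-fold lower number from compound 1 to compound 4 (0.47 log units; beyond the scatter), a step that no earlier pair of compounds could show. This position can therefore shift the reading beyond the usual scatter, towards a stronger inhibitor, although the step is modest. Nothing shown gives a reason for this step. Still open, going by these compounds, is how other groups on this nitrogen would compare, such as cyclopentyl, a phenyl ring or a longer chain like n-hexyl.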